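Swapping Methylsulfanyl for Nitro on the Aryl Ketone

The source may hold more compounds than are shown below. What is called first, only, known or untested is meant among the compounds shown, and "the series" means these compounds.

Compound 2 `CSc1ccc(C(=O)/C=C/c2ccc3c(c2)B(O)OC3)cc1` carries a methylsulfanyl group on the aryl ketone. In a functional assay on MDA-MB-231 cells (Homo sapiens) for cytotoxicity, read by MTT assay, with a stated time of 48 h (on this read-out higher numbers stand for weaker inhibition and lower numbers for stronger inhibition), compound 2 gives 9800 nM. Compound 1 `Cc1ccc(C(=O)/C=C/c2ccc3c(c2)B(O)OC3)cc1`, which bears a methyl at that place, gives 6500 nM in this assay, so compound 2 stands with the higher of the two numbers shown, although the gap, a 1.5-fold higher number from compound 1 to compound 2 (0.18 log units; within the scatter), lies within the scatter and the two compounds cannot be told apart on this read-out. Compound 3 `O=C(/C=C/c1ccc2c(c1)B(O)OC2)c1ccc([N+](=O)[O-])cc1` has not yet been measured in this assay. It differs from compound 2 in one place: nitro in place of methylsulfanyl on an aromatic carbon. Among the compounds with values here, the only measured step that bears on a change at this position is a 1.5-fold higher number from compound 1 to compound 2 (0.18 log units; within the scatter), and that step was within the scatter. With nothing else to draw on, compound 3 is expected to show a step of a 1.2-fold lower number from compound 2 to compound 3 (0.09 log units; within the scatter), small and not beyond the scatter in either direction. Compound 3 is therefore estimated at 8000 nM in this assay, with a range from 3000 nM to 20000 nM.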

Compound 3, half-maximal inhibitory concentration: 11200 nM
Compound 3: the middle estimate sits 1.4-fold (0.15 log units) below what was measured, within the range that was stated.
By their numbers in this assay, from the lowest: compounds 1, 2 and 3 (each within the scatter of the next).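

In this assay the nitro group, which brings nitrogen and oxygen to this aromatic carbon, para to a large group, gives a 1.1-fold higher number from compound 2 to compound 3 (0.06 log units; within the scatter) and, set against the methyl group, gives a 1.7-fold higher number from compound 1 to compound 3 (0.24 log units; within the scatter) as well. Within the data shown here, the earlier compounds offered only one pair, methyl and methylsulfanyl, whereas these three groups, which differ in their atoms and in their counted hydrogen-bond acceptors, now form a set in which no member can be told apart from the next on this read-out. Across compound 1, compound 2 and compound 3, then, this change of group at this place has not moved the number beyond the scatter, and no evidence is available that would give a reason for this.

The compounds shown leave open whether an amine, a carboxylic acid or a longer chain such as butyl at this same place would also stay within the scatter or would move the number beyond it. They also leave open whether the same insensitivity would hold for any of these groups on a different carbon of this ring, since all three compounds carry their group at the one place.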